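Swapping a Fluorophenyl for tert-Butyl on the Core

The source may hold more compounds than are shown below. What is called first, only, known or untested is meant among the compounds shown, and "the series" means these compounds.

Compound 1 `C#CC(=O)N1C(c2cccc(F)c2)SC[C@@H]1C(=O)OCC` carries a 3-fluorophenyl group on a saturated ring carbon of the shared core. For the measured compounds named here, in a functional assay on Huh-7 cells (Homo sapiens) for inhibition, read by sulforhodamine B assay (on this read-out lower numbers stand for stronger inhibition and higher numbers for weaker inhibition), compound 1 gives 1400 nM, the second highest of the three numbers measured so far. Its nearest neighbour is compound 2 `C#CC(=O)N1C(C(CC)CCCC)SC[C@@H]1C(=O)OCC`, which in this assay gives 1700 nM; the furthest is compound 3 `C#CC(=O)N1C(C(C)CCC)SC[C@@H]1C(=O)OCC`, which in this assay gives 600 nM.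

Two measured steps replace the 3-fluorophenyl group with an alkyl group that has no ring. The change to 1-ethylpentyl gives a 1.2-fold higher number from compound 1 to compound 2 (0.08 log units; within the scatter), while the change to 1-methylbutyl gives a 2.3-fold lower number from compound 1 to compound 3 (0.37 log units; beyond the scatter). Between the two alkyl groups, a 2.8-fold lower number from compound 2 to compound 3 (0.45 log units; beyond the scatter).

Compound 4 `C#CC(=O)N1C(C(C)(C)C)SC[C@@H]1C(=O)OCC` follows the same idea: tert-butyl in place of 3-fluorophenyl on a saturated ring carbon. Since one alkyl replacement in compound 1 left the number essentially unchanged and the other lowered it modestly, the expected outcome in this assay is a step of a 1.6-fold lower number from compound 1 to compound 4 (0.19 log units; within the scatter), at most a modest lowering and possibly nothing beyond the scatter. Compound 4 is therefore estimated at 900 nM, with a range from 350 nM to 2500 nM.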

Compound 4, half-maximal inhibitory concentration: 800 nM
The estimate for compound 4 lay 1.1-fold (0.05 log units) above the measured number; the measured number falls inside the stated range.
By their numbers in this assay, from the lowest: compounds 3, 4, 1 and 2 (each within the scatter of the next, the first and the last beyond it).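

The tert-butyl group of compound 4 shows that this saturated ring carbon can carry a group with a carbon branched three ways, and with 4 heavy atoms in place of 7, without leaving the scatter of the 3-fluorophenyl group in this assay: the result is a 1.8-fold lower number from compound 1 to compound 4 (0.24 log units; within the scatter). It also sits within the scatter of the 1-methylbutyl group, at a 1.3-fold higher number from compound 3 to compound 4 (0.12 log units; within the scatter), so these two alkyl groups cannot be told apart here, and only the 1-ethylpentyl group stands apart from tert-butyl, with a 2.1-fold lower number from compound 2 to compound 4 (0.33 log units; beyond the scatter). Nothing available explains why these groups give these numbers.

The compounds shown leave open how this position responds to a group carrying an amine or a carboxylic acid, since every group here is built of carbon and hydrogen apart from the single fluorine of compound 1. They also leave open what a smaller group such as methyl, or a saturated ring such as cyclohexyl, would give on the same carbon of the shared core.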